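The source may report more compounds than this note shows. Statements on the series, on what has been measured and on what is new or still open speak of the compounds shown alone.

Measured so far in an assay on isolated protein for inhibition of Polyunsaturated fatty acid 5-lipoxygenase (Homo sapiens), read by HPLC, with a stated time of 15 min; on this read-out higher numbers stand for weaker inhibition and lower numbers for stronger inhibition:
compound 1, `C#CCCCCCOC(=O)/C=C/c1ccc(OC(C)=O)c(OC(C)=O)c1`: > 10000 nM
compound 2, `C#CCCCCCCCCOC(=O)/C=C/c1ccc(OC(C)=O)c(OC(C)=O)c1`: > 10000 nM

In this assay compound 1 gives > 10000 nM, which is a limit of the assay and not a number. Compound 2 likewise gives > 10000 nM, again a limit. For the measured compounds named here, both values sit at the limit of > 10000 nM in this assay, at which 2 of the 2 values shown sit, so the only step among the measured compounds, a step that the two limits leave unreadable from compound 1 to compound 2, cannot be read for size or direction. Compound 2 therefore stands only at a limit, with no number of its own.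

Compound 3 is `CC(=O)Oc1ccc(/C=C/C(=O)OCCCCc2cnnn2CCCO)cc1OC(C)=O`. It differs from compound 2 by 1-(3-hydroxypropyl)-1H-1,2,3-triazol-5-yl in place of hex-5-yn-1-yl on a saturated chain carbon, four bonds along the chain from an oxygen next to a carbonyl group. Going by the values given here, the one measured step bearing on this chain region, a step that the two limits leave unreadable from compound 1 to compound 2, offers no readable size, so no direction beyond the scatter can be expected from it. Compound 3 is therefore estimated at 15000 nM in this assay, with a range from 3000 nM to 60000 nM, an expected step that the limit leaves unreadable from compound 2 to compound 3, most likely reported again as a limit.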

Compound 3, half-maximal inhibitory concentration: 7600 nM
Beside the measured number, compound 3's estimate is 2.0-fold (0.30 log units) above it; measured number inside the range.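

In this assay compound 3 is the first compound shown with a number and not a limit, so 1-(3-hydroxypropyl)-1H-1,2,3-triazol-5-yl on this saturated chain carbon gives the chain region its first readable value. From the compounds shown here alone, replacing hex-5-yn-1-yl with this group gives an at least 1.3-fold lower number from compound 2 to compound 3 (0.11 log units; that floor lies within the scatter), and the corresponding replacement of propargyl gives an at least 1.3-fold lower number from compound 1 to compound 3 (0.11 log units; that floor lies within the scatter); each of these is only a floor, so the true size of the change remains unknown. The other compounds still stand at a limit: the limit of > 10000 nM in this assay, at which 2 of the 3 values shown sit.

The compounds shown leave open whether the five-membered aromatic ring or the 3-hydroxypropyl chain on it accounts for the value of compound 3. A plain propyl chain or an amine in place of the 3-hydroxypropyl chain would help separate the two.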